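The source may report more compounds than this note shows. Statements on the series, on what has been measured and on what is new or still open speak of the compounds shown alone.

Compound 1 `Cc1ccc(S(=O)(=O)n2cnc3c(Cl)ncnc32)cc1` gives 13900 nM in a functional assay on T47D cells (Homo sapiens) for cytotoxicity, read by sulforhodamine B assay, with a stated time of 72 h; on this read-out higher numbers stand for weaker inhibition and lower numbers for stronger inhibition. Compound 2 `Cc1ccc(S(=O)(=O)n2cnc3c(N4CCC(C)CC4)ncnc32)cc1`, carrying 4-methylpiperidin-1-yl in place of chloro on an aromatic carbon, gives 22500 nM in this assay; it stands at the high end of these two numbers, yet a 1.6-fold higher number from compound 1 to compound 2 (0.21 log units; within the scatter) lies within the scatter, so the two are not truly separated. Compound 3 `Cc1ccc(S(=O)(=O)n2cnc3c(NCCC4C=CCCC4)ncnc32)cc1` differs from compound 2 by (2-(cyclohex-2-en-1-yl)ethyl)amino in place of 4-methylpiperidin-1-yl on an aromatic carbon. For the measured compounds named here, only that one earlier swap at the same aromatic carbon bears on this change, and it moved nothing beyond the scatter, so no step beyond the scatter is expected in this assay. Compound 3 is therefore estimated at 20000 nM, with a range from 7000 nM to 60000 nM. This estimate means a 1.1-fold lower number from compound 2 to compound 3 (0.05 log units; within the scatter) is expected.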

Compound 3, half-maximal inhibitory concentration: 34500 nM
Compound 3: middle estimate off by 1.7-fold (0.24 log units), on the low side; the measured number falls inside the stated range.
By their numbers in this assay, from the lowest: compounds 1, 2 and 3 (each within the scatter of the next, the first and the last beyond it).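

In this assay, swapping 4-methylpiperidin-1-yl for (2-(cyclohex-2-en-1-yl)ethyl)amino at this aromatic carbon leaves the two amines unseparated, with a 1.5-fold higher number from compound 2 to compound 3 (0.19 log units; within the scatter). Set against chloro, however, the same position now gives its first step beyond the scatter, a 2.5-fold higher number from compound 1 to compound 3 (0.39 log units; beyond the scatter), a modest move toward weaker inhibition. No measurement available here accounts for this shift.

Still open, from the compounds shown here alone, is whether any group at this carbon can bring the number below that of compound 1. A plain amino group, a methoxy group or a chain ending in a carboxylic acid could test this.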